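Adding a Methyl to Compound 3: the Expected Shift

The source may report more compounds than this note shows. Statements on the series, on what has been measured and on what is new or still open speak of the compounds shown alone.

Of the compounds shown here, three built on one shared core have been measured in a functional assay for antagonist activity at Adrenergic receptor alpha-1 (Rattus norvegicus); on this read-out lower numbers stand for tighter binding and higher numbers for weaker binding. Compound 1, `O=c1cc(-c2ccccc2)oc2cc(OCCCN3CCN(c4ccccc4)CC3)ccc12`, gives 6.65 nM. Compound 2, `Cc1ccc(N2CCN(CCCOc3ccc4c(=O)cc(-c5ccccc5)oc4c3)CC2)cc1`, gives 20.7 nM. Compound 3, `O=c1cc(-c2ccc(Cl)cc2)oc2cc(OCCCN3CCN(c4ccccc4)CC3)ccc12`, gives 8.47 nM. Among these three numbers compound 3 stands second highest; its nearest neighbour is compound 1, separated by only a 1.3-fold higher number from compound 1 to compound 3 (0.11 log units; within the scatter), which lies within the usual scatter, so no order between the two can be claimed. Compound 2 lies further off, with a number higher than that of compound 3 beyond the scatter.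

The unmeasured compound 4, `Cc1ccc(N2CCN(CCCOc3ccc4c(=O)cc(-c5ccc(Cl)cc5)oc4c3)CC2)cc1`, differs from compound 3 in one place: methyl in place of hydrogen on an aromatic carbon. This same change has been made once before among the measured compounds, from compound 1 to compound 2, where it gave a 3.1-fold higher number from compound 1 to compound 2 (0.49 log units; beyond the scatter), a modest move toward weaker binding. Since compound 3 and compound 1 differ only by a chloro group, and that difference was a 1.3-fold higher number from compound 1 to compound 3 (0.11 log units; within the scatter), within the scatter, the methyl step is expected to carry over. For compound 4 the expected step is therefore a 3.1-fold higher number from compound 3 to compound 4 (0.49 log units; beyond the scatter). The estimate for compound 4 is 26 nM, with a likely range from 12 nM to 55 nM.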

Compound 4, dissociation constant: 8.17 nM
Estimate against measurement, compound 4: 3.2-fold (0.50 log units) above; measured number outside the range, below it.
By their numbers in this assay, from the lowest: compounds 1, 4 and 3 (each within the scatter of the next); then compound 2.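

On the core carrying the chloro group, methyl in place of hydrogen on this aromatic carbon, para to a large group, gives a step that stays within the scatter in this assay: a 1.0-fold lower number from compound 3 to compound 4 (0.02 log units; within the scatter). The step from phenyl to 4-methylphenyl therefore has no single size here, and what it does at this position depends on the group carried elsewhere in the molecule: the same change on two cores in this assay, a 3.1-fold higher number (0.49 log units; beyond the scatter) from compound 1 to compound 2 and a 1.0-fold lower number (0.02 log units; within the scatter) from compound 3 to compound 4, 3.2-fold (0.51 log units) apart, beyond the scatter of two such steps. Read the other way, chloro in place of hydrogen gives a step beyond the scatter when the methyl is present, a 2.5-fold lower number from compound 2 to compound 4 (0.40 log units; beyond the scatter), so the two changes do not simply add up: the same change on two cores in this assay, a 1.3-fold higher number (0.11 log units; within the scatter) from compound 1 to compound 3 and a 2.5-fold lower number (0.40 log units; beyond the scatter) from compound 2 to compound 4, 3.2-fold (0.51 log units) apart, beyond the scatter of two such steps.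

The compounds shown leave open whether a fluoro or a methoxy group in place of the chloro would also cancel the methyl step, and whether an ethyl group or an amine in place of the methyl would behave as the methyl does. With only four compounds forming a single square of changes, they also cannot tell whether this dependence between the two positions is general or particular to this pair of groups.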